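This account rests on a few compounds, and the source may have more. Where it says the series, first, only, none or still open, it means among the compounds named here.

Measured compounds:
compound 1, `C=C(Br)C(=O)Nc1cccc(-c2cn3nc(Cc4cccc(OC)c4)sc3n2)c1`, 1100 nM
compound 2, `Nc1cccc(-c2cn3nc(Cc4ccccc4)sc3n2)c1`, 4700 nM
compound 3, `Nc1cccc(-c2cn3nc(Cc4ccc(Cl)cc4)sc3n2)c1`, 6000 nM

All three were tested in a functional assay on FM3A cells (Mus musculus) for inhibition, read by cell counting, with a stated time of 2 days; on this read-out higher numbers stand for weaker inhibition and lower numbers for stronger inhibition. For the measured compounds named here, compound 3 gives the highest of the three numbers; compound 2 gives a value that lies within the scatter of it, while compound 1 gives a clearly lower number, differing from compound 3 in two places at once, so no single-point step links those two. Compound 4, `COc1cccc(Cc2nn3cc(-c4cccc(N)c4)nc3s2)c1`, is not yet measured. It differs from compound 3 by 3-methoxyphenyl in place of 4-chlorophenyl on a saturated chain carbon bound to an aromatic carbon. Going by the values given here, the one measured step at the same place, a 1.3-fold higher number from compound 2 to compound 3 (0.11 log units; within the scatter), shows that a change in the group on that saturated chain carbon left the result essentially unchanged. Nothing measured isolates the effect of the 3-methoxyphenyl group on its own, since compound 1 also carries a different group on the aromatic amine. The expectation is therefore a small step, a 1.3-fold lower number from compound 3 to compound 4 (0.12 log units; within the scatter), within the usual scatter. Compound 4 is estimated at 4500 nM, with a range from 1500 nM to 12000 nM.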

Compound 4, half-maximal inhibitory concentration: 10000 nM
Beside the measured number, compound 4's estimate is 2.2-fold (0.35 log units) below it, and the stated range covers the measured number.
By their numbers in this assay, from the lowest: compound 1; then compounds 2, 3 and 4 (each within the scatter of the next, the first and the last beyond it).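

In this assay, putting 3-methoxyphenyl in place of 4-chlorophenyl on a saturated chain carbon bound to an aromatic carbon gives a 1.7-fold higher number from compound 3 to compound 4 (0.22 log units; within the scatter), so these two groups cannot be told apart here. Adding a methoxy group as the only change gives a 2.1-fold higher number from compound 2 to compound 4 (0.33 log units; beyond the scatter), the first step at this part of the molecule that lies beyond the scatter, though it is modest and points towards weaker inhibition. With 3-methoxyphenyl now held constant, hydrogen in place of (1-bromoethenyl)carbonyl on the nitrogen gives a 9.1-fold higher number from compound 1 to compound 4 (0.96 log units; beyond the scatter), which ties the lower number of compound 1 to that nitrogen group rather than to the methoxy.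

Nothing available explains the size of any of these steps. Also open, from the compounds shown here alone, are how a hydroxy group or a nitrile on that aromatic ring would read, and whether a longer chain in place of the saturated chain carbon would change the result.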